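Tert-butyl in place of propyl on the amide nitrogen

A few compounds are considered here, and "the series" means these few. Any claim that something is new, unique, unknown or untested is made for them only; others in the source may bear on it.

Compound 3 `CCCNC(=O)N(CCCCCCN1C[C@H](O)[C@@H](O)[C@H](O)[C@H]1CO)C1CCCCC1` was tested in an ADME assay on Huh-7 cells (Homo sapiens) for cytotoxicity, read by MTT assay; on this read-out higher numbers stand for lower toxicity in this test and lower numbers for higher toxicity in this test. In this assay compound 3 gives > 500000 nM, which is a limit of the assay and not a number. Two related compounds on the same core were tested alongside it. Compound 1 `O=C(c1ccccc1)N(CCCCCCN1C[C@H](O)[C@@H](O)[C@H](O)[C@H]1CO)C1CCCCC1` carries a phenyl on the carbonyl carbon. In this assay compound 1 gives > 500000 nM, again a limit. Compound 2 `NC(=O)N(CCCCCCN1C[C@H](O)[C@@H](O)[C@H](O)[C@H]1CO)C1CCCCC1` carries an amino group on the carbonyl carbon. In this assay compound 2 gives > 500000 nM, also a limit. Compound 3 thus stands where every measured value stands, namely at the limit of > 500000 nM in this assay, at which 3 of the 3 values shown sit. The steps a step that the two limits leave unreadable from compound 1 to compound 2, a step that the two limits leave unreadable from compound 1 to compound 3 and a step that the two limits leave unreadable from compound 2 to compound 3 are for that reason all of unreadable size.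

Compound 4 `CC(C)(C)NC(=O)N(CCCCCCN1C[C@H](O)[C@@H](O)[C@H](O)[C@H]1CO)C1CCCCC1` differs from compound 3 in one place: tert-butyl in place of propyl on an amide-type nitrogen. For the measured compounds named here, of the measured steps, only the one that changes the substituent on the amide-type nitrogen, a step that the two limits leave unreadable from compound 2 to compound 3, bears directly on this change, and its size cannot be read. Since the three measured compounds show no step beyond the scatter, the expected step in this assay is a step that the limit leaves unreadable from compound 3 to compound 4, none beyond the scatter. Compound 4 is therefore estimated at 600000 nM, in a range from 300000 nM to 1500000 nM, and is expected to be reported once more as a limit.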

Compound 4, half-maximal cytotoxic concentration: > 500000 nM
Compound 4 was reported as a limit; the forecaster's own chance of this, stated with the estimate: 85%; the middle value does not contradict the limit.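

In this assay compound 4 gives > 500000 nM, which is a limit of the assay and not a number. No step from compound 1, compound 2 or compound 3 to compound 4 can be read, and all four compounds stand at the same limit: the limit of > 500000 nM in this assay, at which 4 of the 4 values shown sit.

The compounds shown leave open how far any of them lies past that limit, and whether changing the group on the carbonyl carbon alters the result in this assay at all.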